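The source may report more compounds than this note shows. Statements on the series, on what has been measured and on what is new or still open speak of the compounds shown alone.

In a functional assay on HeLa cells (Homo sapiens) for cytotoxicity, read by resazurin assay, with a stated time of 72 h (on this read-out higher numbers stand for weaker inhibition and lower numbers for stronger inhibition), compound 1 `CCCC(=S)SCC(=O)c1ccc(OC)cc1` gives 5710 nM, compound 2 `CCOC(=S)SCC(=O)c1ccc(OC)cc1` gives 4640 nM and compound 3 `CCNC(=S)SCC(=O)c1ccc(OC)cc1` gives 7800 nM. Compound 3 therefore cannot be told apart from the other two. Compound 4 `CCOC(=O)SCC(=O)c1ccc(OC)cc1` changes one group of compound 3: a group of 5 heavy atoms (3 carbon, 2 oxygen; no ring) in place of a group of 5 heavy atoms (3 carbon, 1 nitrogen, 1 sulfur; no ring), on a sulfur. Three measured swaps on the thiocarbonyl carbon bear on this: a 1.2-fold lower number from compound 1 to compound 2 (0.09 log units; within the scatter), a 1.4-fold higher number from compound 1 to compound 3 (0.14 log units; within the scatter) and a 1.7-fold higher number from compound 2 to compound 3 (0.23 log units; within the scatter). All three stay within the scatter. On these data alone, none of them replaces the thiocarbonyl itself, so that part of the change is untested. A step beyond the scatter is therefore not expected in this assay. The expected change is small: a 1.1-fold lower number from compound 3 to compound 4 (0.05 log units; within the scatter). For compound 4 the estimated value is 7000 nM, with an expected range from 3000 nM to 16000 nM.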

Compound 4, half-maximal inhibitory concentration: 18500 nM
Estimate against measurement, compound 4: 2.6-fold (0.42 log units) below; measured number above the stated range.
By their numbers in this assay, from the lowest: compounds 2, 1 and 3 (each within the scatter of the next); then compound 4.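

In this assay, among the compounds shown here, a carbonyl in place of the thiocarbonyl, with the ethoxy kept, gives a 4.0-fold higher number from compound 2 to compound 4 (0.60 log units; beyond the scatter) and is the first step here beyond the scatter. Compound 4 also stands apart with a 2.4-fold higher number from compound 3 to compound 4 (0.38 log units; beyond the scatter) and a 3.2-fold higher number from compound 1 to compound 4 (0.51 log units; beyond the scatter) while the three thiocarbonyl compounds stay within the scatter of one another, so in this set, swapping the thiocarbonyl matters more than swapping the group attached to it. Nothing shown explains this loss of inhibition. Still open, on these data alone, is whether a carbonyl has the same effect when carrying propyl or ethylamino. Also open, as far as these compounds go, is how a longer chain, such as hexyl, or a carboxylic acid would behave on that carbon.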